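Swapping 3-aminophenyl for thiophen-2-yl

A few compounds are considered here, and "the series" means these few. Any claim that something is new, unique, unknown or untested is made for them only; others in the source may bear on it.

Compound 1 `COc1ccc(-c2nc3cccc(-c4cc(OC)c(OC)c(OC)c4)c3o2)cc1OC`: > 25000 nM (a limit)
Compound 2 `COc1cc(-c2cccc3nc(-c4ccc(Br)cc4)oc23)cc(OC)c1OC`: > 25000 nM (a limit)
Compound 3 `COc1cc(-c2cccc3nc(-c4cccc(N)c4)oc23)cc(OC)c1OC`: 2600 nM

Among the measured compounds shown here, in a functional assay on NCI-H460 cells (Homo sapiens) for antiproliferative activity, read by MTT assay, with a stated time of 48 h (a higher number here means a weaker inhibitor, a lower number a stronger inhibitor), compound 3 gives 2600 nM, the only true number so far. The other two compounds stop at a limit: the limit of > 25000 nM in this assay, at which 2 of the 3 values shown sit.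

Compound 4 `COc1cc(-c2cccc3nc(-c4cccs4)oc23)cc(OC)c1OC` changes one group of compound 3: thiophen-2-yl in place of 3-aminophenyl on an aromatic carbon. Thiophen-2-yl sits on an aromatic carbon, next to the ring nitrogen and next to the ring oxygen.

For the measured compounds named here, two measured steps bear on this change: an at least 9.6-fold lower number from compound 1 to compound 3 (0.98 log units; beyond the scatter) and an at least 9.6-fold lower number from compound 2 to compound 3 (0.98 log units; beyond the scatter). Both lie beyond the scatter, and both bring in 3-aminophenyl. Going by the values given here, compound 3 at 2600 nM is the only measured compound with that group, and compound 4 gives it up, so a higher number is expected. Among the compounds with values here, no measured compound carries thiophen-2-yl, which leaves the size uncertain, and a result at the limit is quite possible.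

The expected change is a 5.4-fold higher number from compound 3 to compound 4 (0.73 log units; beyond the scatter), a weaker result. For compound 4 the estimate in this assay is 14000 nM, with an expected range from 4000 nM to 25000 nM.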

Compound 4, half-maximal inhibitory concentration: 1600 nM
Compound 4: the middle estimate sits 8.8-fold (0.94 log units) above what was measured, outside the stated range (below it).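

Thiophen-2-yl in place of 3-aminophenyl gives a 1.6-fold lower number from compound 3 to compound 4 (0.21 log units; within the scatter) in this assay, so a true number at this position does not depend on 3-aminophenyl, and a group with 0 hydrogen-bond donors does as well here as one with 1. Thiophen-2-yl also separates clearly from the other two groups at this position, with an at least 15-fold lower number from compound 2 to compound 4 (1.19 log units; beyond the scatter) and an at least 15-fold lower number from compound 1 to compound 4 (1.19 log units; beyond the scatter). These two steps give only a minimum size, since compound 1 and compound 2 each stop at a limit of the assay: the limit of > 25000 nM in this assay, at which 2 of the 4 values shown sit.

As far as these compounds go, what 3-aminophenyl and thiophen-2-yl have in common that sets them apart from 4-bromophenyl and 3,4-dimethoxyphenyl remains open. Unsubstituted phenyl, 4-aminophenyl or furan-2-yl at this position would help to show whether the ring itself or the groups on it decide the result.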